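The source may hold more compounds than are shown below. What is called first, only, known or untested is meant among the compounds shown, and "the series" means these compounds.

Of the compounds shown here, three have so far been measured in a physicochemical assay for acid dissociation, tested at 10 mM. Compound 1 `Cc1nn(-c2ccccc2)c(SSc2c(C(=O)c3ccccc3)c(C)nn2-c2ccccc2)c1C(=O)c1ccccc1` gives 3.2. Compound 2 `Cc1cc(CCc2cc(C)nn2-c2ccccc2)n(-c2ccccc2)n1` gives 2.5. Compound 3 `Cc1cc(COc2cc(C)nn2-c2ccccc2)n(-c2ccccc2)n1` gives 2.7 in this assay, which places it second highest of the three numbers; the value of compound 2 lies close to it, within the usual scatter of this kind of measurement, so the two cannot be told apart, while the value of compound 1 sits further off, beyond the scatter.

Compound 4 `Cc1cc(COc2cc(C)nn2-c2ccc([N+](=O)[O-])cc2)n(-c2ccccc2)n1` has not yet been measured. It differs from compound 3 in a single place: nitro in place of hydrogen on an aromatic carbon. Among the measured compounds no pair differs by a nitro group alone, so there is no measured step to lean on, and the expectation rests on the structural change itself. In this assay a downward step of moderate size is expected, a number 0.70 log units lower from compound 3 to compound 4 (beyond the scatter), beyond the usual scatter. Compound 4 is therefore expected to give about 2 in this assay, with a plausible range from 1.3 to 2.7. The actual measurement will show whether the expectation holds.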

Compound 4, acid dissociation constant: 2
Estimate against measurement, compound 4: no gap at the digits printed, within the range that was stated.
By their numbers in this assay, from the lowest: compound 4; then compounds 2 and 3 (each within the scatter of the next); then compound 1.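

In this assay, going by these compounds alone, the change from phenyl to 4-nitrophenyl gives the first step in this set that can be tied to a single place: a number 0.70 log units lower from compound 3 to compound 4 (beyond the scatter). Within the data shown here, compound 1, compound 2 and compound 3 offered no pair that differs in one place, so their numbers could be set side by side but no single change could be read from them; this pair shows that an edit at this position, on an aromatic carbon of a six-membered aromatic ring of carbon only and para to a large group, can move the number by more than the usual scatter of the measurement. No measurement shown here bears on why the number moves with this change.

Going by these compounds, one group at one position cannot show whether this step is particular to nitro, so it remains open whether an amine, a nitrile or a carboxylic acid at the same place would move the number in the same direction or by a similar amount. On these data alone, it also remains open whether nitro at this place would give a step of similar size on compound 2, which carries a different link in the middle of the molecule.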